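The source may report more compounds than this note shows. Statements on the series, on what has been measured and on what is new or still open speak of the compounds shown alone.

Measured so far in a functional assay on U-87MG ATCC cells (Homo sapiens) for cytotoxicity, read by MTT assay, with a stated time of 72 h; a higher number here means a weaker inhibitor, a lower number a stronger inhibitor:
compound 1 `COc1ccc(/C=N/NC(=O)Nc2ccc(Oc3ccnc(-c4nncn4CCN(C)C)c3)c(F)c2)c(OC)c1`: 12600 nM
compound 2 `CN(C)CCn1cnnc1-c1cc(Oc2ccc(NC(=O)N/N=C/c3ccc(O)c(O)c3)cc2F)ccn1`: a limit, > 100000 nM
compound 3 `CN(C)CCn1cnnc1-c1cc(Oc2ccc(NC(=O)N/N=C/c3cccc(Cl)c3Cl)cc2F)ccn1`: 13200 nM

Compound 3 carries the higher of the two numbers reported, but the step between them is only a 1.0-fold higher number from compound 1 to compound 3 (0.02 log units; within the scatter), so the two sit within the scatter of each other. Compound 2 is the odd one out: in this assay compound 2 reaches only the limit > 100000 nM (the limit of > 100000 nM in this assay, at which 1 of the 3 values shown sits), and the step from that limit to compound 3 is an at least 7.5-fold lower number from compound 2 to compound 3 (0.87 log units; beyond the scatter).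

Compound 4 `CN(C)CCn1cnnc1-c1cc(Oc2ccc(NC(=O)N/N=C/c3ccc(O)c(F)c3)cc2F)ccn1` is not yet measured. It differs from compound 3 in one place: 3-fluoro-4-hydroxyphenyl in place of 2,3-dichlorophenyl on a carbon with a double bond to nitrogen. Going by the values given here, two measured steps bear on this. The step of a 1.0-fold higher number from compound 1 to compound 3 (0.02 log units; within the scatter) shows that swapping one aryl group without hydroxyls for another leaves the number where it was, while an at least 7.9-fold higher number from compound 1 to compound 2 (0.89 log units; beyond the scatter) and an at least 7.5-fold lower number from compound 2 to compound 3 (0.87 log units; beyond the scatter) show that the 3,4-dihydroxyphenyl ring pushes the number beyond the limit. The group entering in compound 4 keeps a hydroxyl but only one, with fluorine in place of the second. Compound 4 is therefore expected to land between these cases, with a weakening step of about a 3.0-fold higher number from compound 3 to compound 4 (0.48 log units; beyond the scatter) from compound 3, and a real chance that only a limit is returned. The estimate for compound 4 is 40000 nM, with a range from 12000 nM to 130000 nM.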

Compound 4, half-maximal inhibitory concentration: > 100000 nM
Compound 4 ended at the assay's limit; the forecaster's own chance of this, stated with the estimate: 35%; at least 2.5-fold (0.39 log units) between middle value and limit.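

In this assay, the result extends what compound 2 showed at this place, on a carbon with a double bond to nitrogen: a second hydroxyl is not needed for the number to reach the limit, as a 3-fluoro-4-hydroxyphenyl group with fluorine in its place also gets there, with an at least 7.5-fold higher number from compound 3 to compound 4 (0.87 log units; beyond the scatter) and an at least 7.9-fold higher number from compound 1 to compound 4 (0.89 log units; beyond the scatter). Among the four compounds shown, the two aryl groups carrying a hydroxyl sit at the limit and the two without one give measured numbers, and no compound here goes against this pattern. Because compound 2 and compound 4 both stand at a limit, the step between them, fluoro in place of hydroxy on an aromatic carbon, cannot be read, and how far apart they lie stays unknown: the limit of > 100000 nM in this assay, at which 2 of the 4 values shown sit.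

The compounds shown leave open whether the free hydroxyl itself separates these pairs or whether the other substituents on the ring also play a part. A 3-fluoro-4-methoxyphenyl group, or a ring with an amine where the hydroxyl stands, would put that question to a direct comparison with compound 4.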